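Compound 3: a change of configuration, still unmeasured

The compounds below may be only part of what the source reports. "The series", "measured", "known", "first", "only" and "open" are said of these compounds alone.

Measured in a functional assay on MDA-MB-231 cells (Homo sapiens) for inhibition, read by MTT assay, with a stated time of 72 h (on this read-out lower numbers stand for stronger inhibition and higher numbers for weaker inhibition), so far:
compound 1 `COc1ccccc1[C@@H]1CC=CC(=O)[C@]12C(=O)N(c1ccccc1)N=C2C` gives 5140 nM
compound 2 `CC1=NN(c2ccccc2)C(=O)[C@]12C(=O)C=CC[C@H]2c1ccccc1` gives 5800 nM
Not yet measured: compound 3 `CC1=NN(c2ccccc2)C(=O)[C@]12C(=O)C=CC[C@@H]2c1ccccc1`

For the measured compounds named here, only two values exist, and they cannot be told apart. Going by the values given here, compound 2, at 5800 nM, stands level with compound 1, the one other measured compound. Among the compounds with values here, the single measured step is a 1.1-fold higher number from compound 1 to compound 2 (0.05 log units; within the scatter), and it comes with a hydrogen in place of methoxy on an aromatic carbon.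

The next compound keeps every atom and bond of compound 2: the two compounds have the same atoms and bonds and differ only in configuration as drawn: 1 of 2 stereo elements differ; a stereocentre at a saturated ring carbon is drawn S in compound 2 and R in compound 3. Within the data shown here, no measured step touches a change of this kind. Among the measured compounds shown here, the step between the two measured compounds concerns a substituent, so it shows only that this one swap left the value within the scatter. For the measured compounds named here, it gives neither a size nor a direction for a change of configuration, and no measured pair of stereoisomers is available as a guide.

With no evidence for a direction, the expected step is a 1.0-fold higher number from compound 2 to compound 3 (0.01 log units; within the scatter) in this assay and the uncertainty on it is wide. For compound 3 the estimated value is 6000 nM with an expected range from 2500 nM to 15000 nM until the measurement is known.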

Compound 3, half-maximal inhibitory concentration: 9080 nM
Compound 3: middle estimate off by 1.5-fold (0.18 log units), on the low side, within the range that was stated.
By their numbers in this assay, from the lowest: compounds 1, 2 and 3 (each within the scatter of the next).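

For the compounds shown here, this is the first measured pair of stereoisomers, and it gives the change of configuration a size: in this assay the step is a 1.6-fold higher number from compound 2 to compound 3 (0.19 log units; within the scatter). Nothing else can account for the step, since the atoms and bonds stay the same and a single stereocentre at a saturated ring carbon is drawn the other way: the fact that compounds 2 and 3 differ only in the configuration as drawn The two compounds therefore cannot be told apart in this assay, so at this position the drawn configuration, like the earlier swap of hydrogen for methoxy on an aromatic carbon, has no effect that can be separated from the scatter.

The compounds shown leave open what happens when the second stereo element is inverted, alone or together with the first, and whether the methoxy compound would give the same result with its stereocentre drawn the other way. They also leave open whether an amine, a carboxylic acid or a longer chain on the aromatic ring would give a value that stands clear of the scatter, and whether configuration would matter more in such a compound.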